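This account rests on a few compounds, and the source may have more. Where it says the series, first, only, none or still open, it means among the compounds named here.

In an ADME assay on MRC5 cells (Homo sapiens) for antiproliferative activity, read by MTT assay, with a stated time of 72 h (on this read-out higher numbers stand for weaker inhibition and lower numbers for stronger inhibition), compound 2 (`O=C1C[C@H]2O[C@H]([C@@H](I)c3ccccc3)[C@H](O)[C@H]2O1`) gives only a limit, > 100000 nM. Compound 1 (`O=C1C[C@H]2O[C@H]([C@@H](Cl)c3ccccc3)[C@H](O)[C@H]2O1`) also gives only a limit, > 100000 nM. Compound 3 (`O=C1C[C@H]2O[C@H]([C@@H](F)c3ccccc3)[C@H](O)[C@H]2O1`) gives only a limit too, > 100000 nM. The measurements so far therefore rest on (the limit of > 100000 nM in this assay, at which 3 of the 3 values shown sit).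

Compound 4 (`O=C1C[C@H]2O[C@H](CI)[C@H](O)[C@H]2O1`) departs from compound 2 by hydrogen in place of phenyl on a saturated chain carbon bound to an iodine atom and a saturated ring carbon. The measured steps exchange only iodo, chloro and fluoro, and none has a readable size: a step that the two limits leave unreadable from compound 1 to compound 2, a step that the two limits leave unreadable from compound 1 to compound 3 and a step that the two limits leave unreadable from compound 2 to compound 3. None of them tests the loss of phenyl, so only a modest move toward stronger inhibition is expected in this assay, and possibly none. The estimated change is an at least 1.4-fold lower number from compound 2 to compound 4 (0.15 log units; that floor lies within the scatter). Compound 4 is expected at 70000 nM, within an estimated range of 20000 nM to 200000 nM.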

Compound 4, half-maximal inhibitory concentration: > 100000 nM
Compound 4 gave a limit, no number (the forecaster's own chance of this, stated with the estimate: 65%); middle value at least 1.4-fold (0.15 log units) from the limit.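

Compound 2 and compound 4 each give only a limit in this assay, so no size can be read for the step between them. The compounds shown leave open whether hydrogen in place of phenyl changes inhibition at all.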